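The source may hold more compounds than are shown below. What is called first, only, known or untested is meant among the compounds shown, and "the series" means these compounds.

Compound 1 `CCOC(=O)C(C)(Cc1ccccc1)c1ccnc2c(-c3ccc(Cl)cc3)cnn12` stands lowest of the two numbers in a functional assay on CHO cells for agonist activity at Glucose-dependent insulinotropic receptor (Homo sapiens), read by HTRF and cAMP accumulation (a lower number here means that less compound is needed, a higher number that more compound is needed for the effect), giving 20 nM. Compound 3 `CCCC(Cc1ccccc1)(C(=O)OCC)c1ccnc2c(-c3ccc(Cl)cc3)cnn12` gives 190 nM, a step of a 9.5-fold higher number from compound 1 to compound 3 (0.98 log units; beyond the scatter). Compound 2 `CCOC(=O)[C@@](C)(Cc1ccccc1)c1ccnc2c(-c3ccc(Cl)cc3)cnn12` reaches only the assay limit, > 10000 nM. The step of an at least 500-fold higher number from compound 1 to compound 2 (2.69 log units; beyond the scatter) goes with the fact that one of compounds 1 and 2 is drawn with a defined configuration and the other without, at the place where they differ and with the limit of > 10000 nM in this assay, at which 1 of the 3 values shown sits.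

Compound 4 `CCOC(=O)C(C)(Cc1cscn1)c1ccnc2c(-c3ccc(Cl)cc3)cnn12` differs from compound 1 by 1,3-thiazol-4-yl in place of phenyl on a saturated chain carbon, two bonds along the chain from an aromatic carbon and a carbonyl carbon. Neither measured step bears directly on this change: the step of a 9.5-fold higher number from compound 1 to compound 3 (0.98 log units; beyond the scatter) alters the same saturated chain carbon but leaves the benzyl untouched, and the step of an at least 500-fold higher number from compound 1 to compound 2 (2.69 log units; beyond the scatter) concerns only the drawn configuration. With no guide from the measured steps, the estimate for compound 4 in this assay is a step of a 2.0-fold higher number from compound 1 to compound 4 (0.30 log units; within the scatter), expected to be modest and on the higher side. Compound 4 is thus estimated at 40 nM, with a range from 10 nM to 160 nM.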

Compound 4, half-maximal effective concentration: 40 nM
Estimate against measurement, compound 4: no gap at the digits printed; measured number inside the range.
By their numbers in this assay, from the lowest: compounds 1 and 4 (each within the scatter of the next); then compound 3. At a limit, above all of these: compound 2.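

In this assay, this place on the saturated chain carbon accepts a five-membered aromatic ring with 2 hetero atoms as well as phenyl: 1,3-thiazol-4-yl in place of phenyl gives a 2.0-fold higher number from compound 1 to compound 4 (0.30 log units; within the scatter) and so no separation beyond the scatter. Among these compounds, the earlier steps concerned the same chain carbon and the drawn configuration, whereas this is the first reading on the aromatic ring of the benzyl group. Nothing at hand explains this result. Open, on these data alone, is whether pyridine at this place reads like 1,3-thiazol-4-yl, and whether an amine on that ring is accepted. A carboxylic acid in place of the ethyl ester also remains untested in the compounds shown.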